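The compounds below may be only part of what the source reports. "The series", "measured", "known", "first", "only" and "open" are said of these compounds alone.

Measured in a functional assay on A549 cells (Homo sapiens) for cytotoxicity, read by MTT assay, with a stated time of 72 h; on this read-out lower numbers stand for stronger inhibition and higher numbers for weaker inhibition:
Compound 1 `O=C(Nc1ccc(Oc2ccnc3[nH]ccc23)cc1)c1nccc(-c2ccc(Cl)cc2)n1` gives 22400 nM.
Compound 2 `Cc1ccc(-c2cc(C(=O)Nc3ccc(Oc4ccnc5[nH]ccc45)cc3)ncn2)cc1` gives 5410 nM.
Compound 3 `O=C(Nc1ccc(Oc2ccnc3[nH]ccc23)c(F)c1)c1nccc(-c2ccc([N+](=O)[O-])cc2)n1` gives 4470 nM.

Compound 3 has the lowest number of the three. Against compound 2 the difference lies within the scatter, so no order between those two can be read. Against compound 1 the gap lies beyond the scatter; compound 1 is the only member whose value stands clearly apart. Within the data shown here, the measured compounds differ from one another in more than one place, so no single-change step between any two of them is available.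

Compound 4 `O=C(Nc1ccc(Oc2ccnc3[nH]ccc23)c(F)c1)c1nccc(-c2ccc(Cl)cc2)n1` is not yet measured. It differs from compound 3 in one place: chloro in place of nitro on an aromatic carbon. Among the measured compounds shown here, no measured pair isolates this exchange, so its size and direction cannot be taken from the series itself. For the measured compounds named here, the only other compound carrying the chloro group, compound 1, sits at the high end of the numbers, but compound 1 also lacks the fluorine that compound 3 carries, so it does not speak for the exchange alone. The step of a 1.8-fold higher number from compound 3 to compound 4 (0.25 log units; within the scatter) is expected to be a modest rise in the number. Compound 4 is estimated at 8000 nM, with a range from 3000 nM to 25000 nM.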

Compound 4, half-maximal inhibitory concentration: 8940 nM
Compound 4: the middle estimate sits 1.1-fold (0.05 log units) below what was measured, and the stated range covers the measured number.
By their numbers in this assay, from the lowest: compounds 3, 2 and 4 (each within the scatter of the next); then compound 1.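

In this assay, the exchange of 4-nitrophenyl for 4-chlorophenyl gives a 2.0-fold higher number from compound 3 to compound 4 (0.30 log units; within the scatter), so in this pair the two groups cannot be told apart at this position on the aromatic ring. Among these compounds, with chloro held constant, fluoro in place of hydrogen on an aromatic carbon gives a 2.5-fold lower number from compound 1 to compound 4 (0.40 log units; beyond the scatter), the first single-change reading to lie beyond the scatter. The high value of compound 1 therefore cannot be assigned to the chloro group alone, since the pair shows that it also depends on the fluoro exchange, though no supporting measurement bears on the reason for either step.

The compounds shown leave open whether the fluoro step carries over when 4-nitrophenyl replaces 4-chlorophenyl, since this pair reads that exchange only with chloro present. They also leave open whether an amine, a methoxy group or a carboxylic acid on the same aromatic carbon would separate from chloro and nitro by more than the scatter.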